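Cyano-to-fluoro swap at the phenoxy ring of the series

The source may hold more compounds than are shown below. What is called first, only, known or untested is meant among the compounds shown, and "the series" means these compounds.

Measured compounds in a functional assay on cells for antagonist activity at Free fatty acid receptor 1 (Homo sapiens), read by TR-FRET and inositol phosphate accumulation, with a stated time of 2 h; a higher number here means a weaker inhibitor, a lower number a stronger inhibitor:
Compound 1, `Cc1cc(COc2ccccc2C#N)nc(-c2ccccn2)n1`, gives 10000 nM.
Compound 2, `Cc1cc(COc2ccc(C#N)cc2)nc(-c2ccccn2)n1`, gives 31600 nM.
Compound 3, `CC(=O)Nc1ccccc1OCc1cc(C)nc(-c2ccccn2)n1`, gives only a limit of the assay, > 39800 nM.

Compound 2 stands highest of the two numbers in this assay; the nearest is compound 1 with a value beyond the scatter below it, and the value of compound 3 is a limit rather than a number. Within the data shown here, the one measured step that touches the cyano group is an at least 3.9-fold higher number from compound 1 to compound 3 (0.59 log units; beyond the scatter), which ends at the limit noted in the limit of > 39800 nM in this assay, at which 1 of the 3 values shown sits.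

Compound 4, `Cc1cc(COc2ccc(F)cc2)nc(-c2ccccn2)n1`, is not yet measured. It differs from compound 2 by fluoro in place of cyano on an aromatic carbon. Among the measured compounds shown here, no measured pair shows fluoro entering anywhere; the only step removing a cyano, from compound 1 to compound 3, gave a weaker inhibitor and reached the assay limit. Since compound 2 already sits close to that limit, the expected outcome for compound 4 in this assay is a modest further weakening, a 1.6-fold higher number from compound 2 to compound 4 (0.20 log units; within the scatter), with a real chance that only a limit is reported. The estimate for compound 4 is 50000 nM, ranging from 15000 nM to 200000 nM.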

Compound 4, half-maximal inhibitory concentration: 631 nM
For compound 4 the middle estimate is 79-fold (1.90 log units) above the measured one; measured number outside the range, below it.
By their numbers in this assay, from the lowest: compound 4; then compound 1; then compound 2. At a limit, above all of these: compound 3.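

In this assay, the exchange on the aromatic carbon para to a large group gives a 50-fold lower number from compound 2 to compound 4 (1.70 log units; beyond the scatter), so this position can turn a compound from the weak end of the series into a much stronger inhibitor through a single substituent. Among these compounds, the change is small when counted: cyano leaves with its 2 heavy atoms, its triple bond and its hydrogen-bond acceptor, and fluoro enters as 1 heavy atom with no acceptor, yet no earlier measured step led to a lower number at all. Nothing measured here accounts for the size of this step.

From the compounds shown here alone, what remains open is whether the gain is particular to fluoro or would also appear with chloro, methyl, methoxy or trifluoromethyl on the same carbon, since only cyano and fluoro are compared at this position. Going by these compounds, it is equally open whether fluoro on the ring carbon that carries the cyano in compound 1 would bring a step of similar size, and whether the gain at this position would hold with an amine in place of the methyl on the shared core.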